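The source may report more compounds than this note shows. Statements on the series, on what has been measured and on what is new or still open speak of the compounds shown alone.

Compound 1, `CC(C)CC(=O)NC1=NN(C(=O)CC(C)C)C(C)(c2ccccc2)S1`: 190 nM
Compound 2, `CC(C)(C)C(=O)NC1=NN(C(=O)C(C)(C)C)C(CC#N)(c2ccccc2)S1`: "not determined" (no result reported)

Among the compounds with values here, only one number exists so far. In a functional assay on HCT-116 cells (Homo sapiens) for inhibition (a lower number here means a stronger inhibitor of growth, a higher number a weaker inhibitor of growth), compound 1 gives 190 nM. For compound 2 the entry reads "not determined" (no result reported), so no single number places it; where it stands relative to compound 1 cannot be told from what is known.

Compound 3, `COCC1(c2ccccc2)SC(NC(=O)C(C)(C)C)=NN1C(=O)C(C)(C)C`, is the next compound to be measured. It differs from compound 2 in one place: methoxy in place of cyano on a saturated chain carbon bound to a saturated ring carbon. Within the data shown here, no measured pair shows what this exchange does in this assay, and compound 2 itself carries no value, so nothing anchors the step. With the two groups being of like size and each carrying one acceptor, the step is expected to stay within the usual scatter, in no set direction. On that basis compound 3 is estimated at 500 nM in this assay, within a wide range from 80 nM to 3000 nM.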

Compound 3, concentration for 50% growth inhibition: 560 nM
Compound 3: middle estimate off by 1.1-fold (0.05 log units), on the low side, within the range that was stated.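

No step can be read from compound 2 to compound 3, as compound 2 carries no number to compare with. No other finding available bears on this result. In this assay the compounds shown leave open what exchanging cyano for methoxy does.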